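A few compounds are considered here, and "the series" means these few. Any claim that something is new, unique, unknown or untested is made for them only; others in the source may bear on it.

Working notes on the series. Compound 1, `C#CCSc1nc(Nc2cccc(C(F)(F)F)c2)c(C#N)c(-c2ccccc2)n1`, and compound 2, `C#CCSc1nc(Nc2ccc(Cl)cc2)c(C#N)c(-c2ccccc2)n1`, share one core and differ only in the aryl group carried on the amine. In a functional assay on ECa-109 cells (Homo sapiens) for inhibition, read by MTT assay, with a stated time of 72 h (on this read-out lower numbers stand for stronger inhibition and higher numbers for weaker inhibition), compound 1 gives > 128000 nM, which is a limit of the assay and not a number. In this assay compound 2 likewise gives > 128000 nM, again a limit and not a number. Going by the values given here, compound 2 therefore stands nowhere on a scale of numbers; both values shown sit at the same limit, as the limit of > 128000 nM in this assay, at which 2 of the 2 values shown sit, records, and no measured step between the two can be sized.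

Compound 3, `C#CCSc1nc(Nc2cccc(Cl)c2)c(C#N)c(-c2ccccc2)n1`, is the next entry. The change from compound 2 is 3-chlorophenyl in place of 4-chlorophenyl on a nitrogen on an aromatic ring. With both neighbours at the limit, the step expected as a step that the limit leaves unreadable from compound 2 to compound 3 is none beyond the scatter. Compound 3 is estimated at 150000 nM, within a range of 60000 nM to 400000 nM, most probably reported as a limit again.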

Compound 3, half-maximal inhibitory concentration: > 128000 nM
Compound 3: a limit, no number; the forecaster's own chance of this, stated with the estimate: 80%; the middle value is on the limit's open side.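

In this assay, going by these compounds alone, compound 3 gives a limit and not a number, so no step linking it to compound 1 or compound 2 can be read: the limit of > 128000 nM in this assay, at which 3 of the 3 values shown sit.

The compounds shown leave open whether any aryl group on the amine of the shared core gives a readable value in this assay at all.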